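Working notes: from isopropoxy to methylsulfanyl

The source may report more compounds than this note shows. Statements on the series, on what has been measured and on what is new or still open speak of the compounds shown alone.

Values so far in a functional assay on HeLa cells (Homo sapiens) for antiproliferative activity, read by MTT assay, with a stated time of 72 h (on this read-out higher numbers stand for weaker inhibition and lower numbers for stronger inhibition), are
- compound 1 `COc1cccc(-c2ncnn2-c2cc(OC)c(OC)c(OC)c2)c1` at > 10000 nM (a limit)
- compound 2 `COc1cc(-n2ncnc2-c2ccc(OC(C)C)cc2)cc(OC)c1OC` at 600 nM (a number)

For the measured compounds named here, compound 2 holds the only number in this assay so far. The entry for compound 1 is a limit.

The change methylsulfanyl in place of isopropoxy on an aromatic carbon puts methylsulfanyl in place of isopropoxy on an aromatic carbon, para to a large group, and turns compound 2 into compound 3 `COc1cc(-n2ncnc2-c2ccc(SC)cc2)cc(OC)c1OC` for testing. Going by the values given here, no measured step bears on this change. The estimated step of a 3.0-fold lower number from compound 2 to compound 3 (0.48 log units; beyond the scatter) is a modest move toward stronger inhibition in this assay and remains uncertain. For compound 3 the expected value is 200 nM with an estimated range of 30 nM to 1500 nM for now.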

Compound 3, half-maximal inhibitory concentration: 150 nM
For compound 3 the middle estimate is 1.3-fold (0.12 log units) above the measured one; low and high end bracket the measured number.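

In this assay, for the compounds shown here, methylsulfanyl in place of isopropoxy gives a 4.0-fold lower number from compound 2 to compound 3 (0.60 log units; beyond the scatter), the first measured step at this position, and it lies beyond the scatter. With 4-(methylsulfanyl)phenyl in place of 3-methoxyphenyl, the series shows an at least 66-fold lower number from compound 1 to compound 3 (1.82 log units; beyond the scatter), a step that changes both the substituent and its place on the ring. The entry for compound 1 is a limit of the assay: the limit of > 10000 nM in this assay, at which 1 of the 3 values shown sits.

The compounds shown leave open how an ethylsulfanyl group or a dimethylamino group at this position would read. They also cannot separate the share of substituent and place in the step from the limit.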